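The source may report more compounds than this note shows. Statements on the series, on what has been measured and on what is new or still open speak of the compounds shown alone.

Compound 1, `CC(C)N(Cc1cccc(OCCCCCC(=O)O)c1)C(=O)c1ccccc1`, in an ADME assay on HEK293 cells (Homo sapiens) for cytotoxicity, read by CellTiter-Glo and resazurin assay, with a stated time of 72 h (a higher number here means that more compound is needed for the effect, a lower number that less compound is needed), gives > 26000 nM, which is a limit of the assay and not a number.
Compound 2, `CC(C)N(Cc1cccc(OCCCCCC(=O)O)c1)C(=O)c1ccc(-c2ccncc2)cc1`, in this assay gives > 26000 nM, again a limit.
Compound 3, `CC(C)N(Cc1cccc(OCCCCCC(=O)O)c1)C(=O)c1ccc(-c2ccsc2)cc1`, in this assay gives > 26000 nM, also a limit.

Compound 3 therefore stands only at a limit, with no number of its own, and the same holds for the two compounds beside it: the limit of > 26000 nM in this assay, at which 3 of the 3 values shown sit. The steps between the measured compounds cannot be read for that reason: a step that the two limits leave unreadable from compound 1 to compound 2, a step that the two limits leave unreadable from compound 1 to compound 3 and a step that the two limits leave unreadable from compound 2 to compound 3.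

Compound 4, `CC(C)N(Cc1cccc(OCCCCCC(=O)O)c1)C(=O)c1ccc(-c2ccc3[nH]ccc3c2)cc1`, differs from compound 3 in one place: 1H-indol-5-yl in place of thiophen-3-yl on an aromatic carbon. Within the data shown here, none of the measured steps gives a readable size, so no direction can be taken from them; what they do show is that three compounds of this shared core all sit at the limit. Compound 4 is expected to behave the same way, with an expected step that the limit leaves unreadable from compound 3 to compound 4 in this assay. The expected value for compound 4 in this assay is 30000 nM, in a range from 10000 nM to 100000 nM, most likely reported again as a limit rather than a number.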

Compound 4, half-maximal effective concentration: > 26000 nM
Compound 4: only a limit was reported (the forecaster's own chance of this, stated with the estimate: 75%); the middle value does not contradict the limit.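

In this assay compound 4 gives > 26000 nM, again a limit and not a number. Among these compounds, no step between compound 1, compound 2, compound 3 and compound 4 can be read, because all four share one limit: the limit of > 26000 nM in this assay, at which 4 of the 4 values shown sit. The compounds shown leave open what number each would have, and whether they differ from one another at all.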